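This account rests on a few compounds, and the source may have more. Where it says the series, first, only, none or still open, it means among the compounds named here.

Measured compounds:
Compound 1 `COC(=O)[C@@]1(C)CC[C@@H]2C3=C1CC[C@@H](C)[C@]3(C)Cc1c2[nH]c2ccccc12` gives 3400 nM in a functional assay on T47D cells (Homo sapiens) for inhibition, read by sulforhodamine B assay, with a stated time of 48 h; a higher number here means a weaker inhibitor of growth, a lower number a stronger inhibitor of growth.
Compound 2 `COC(=O)[C@@]1(C)CC[C@@H]2C3=C1CC[C@@H](C)[C@]3(C)Cc1c2[nH]c2c(C)cccc12` gives 23000 nM in this assay.
Compound 3 `COC(=O)[C@@]1(C)CC[C@@H]2C3=C1CC[C@@H](C)[C@]3(C)Cc1c2[nH]c2c(Br)cccc12` gives 31000 nM in this assay.

Compound 3 has the highest number of the three, but its number and that of compound 2 are within the scatter of each other, so the two cannot be set apart; only compound 1 stands clearly lower, as shown by a 9.1-fold higher number from compound 1 to compound 3 (0.96 log units; beyond the scatter) and a 6.8-fold higher number from compound 1 to compound 2 (0.83 log units; beyond the scatter). The step of a 1.3-fold higher number from compound 2 to compound 3 (0.13 log units; within the scatter) is within the scatter.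

Compound 4 `COC(=O)[C@@]1(C)CC[C@@H]2C3=C1CC[C@@H](C)[C@]3(C)Cc1c2[nH]c2c(Cl)cccc12` differs from compound 3 in one place: chloro in place of bromo on an aromatic carbon. For the measured compounds named here, no measured step exchanges one halogen for another. The two changes at this position that were measured, methyl in place of hydrogen and bromo in place of hydrogen, gave numbers close to one another, and the step between them was within the scatter. On that basis compound 4 is expected to stay close to compound 3, with a step of a 1.2-fold lower number from compound 3 to compound 4 (0.08 log units; within the scatter) that is not expected to go beyond the scatter. The estimate for compound 4 in this assay is 26000 nM, with a range from 10000 nM to 65000 nM.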

Compound 4, concentration for 50% growth inhibition: 21000 nM
Compound 4: the middle estimate sits 1.2-fold (0.09 log units) above what was measured; the range from low to high includes it.
By their numbers in this assay, from the lowest: compound 1; then compounds 4, 2 and 3 (each within the scatter of the next).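

Exchanging one halogen for the other on this aromatic carbon can now be read directly, and a 1.5-fold lower number from compound 3 to compound 4 (0.17 log units; within the scatter) means that bromo and chloro cannot be set apart in this assay. Chloro also cannot be set apart from methyl, with a 1.1-fold lower number from compound 2 to compound 4 (0.04 log units; within the scatter), so three different groups now sit together at this position. Against hydrogen, a 6.2-fold higher number from compound 1 to compound 4 (0.79 log units; beyond the scatter) places chloro with the other two: all three compounds that carry a group here have a clearly higher number than compound 1, and no compound shown goes against this.

From the compounds shown here alone, whether fluoro, a methoxy group or an amine on this carbon would follow the same pattern remains open. Nothing shown explains why these three groups behave alike.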